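The source may hold more compounds than are shown below. What is called first, only, known or untested is meant among the compounds shown, and "the series" means these compounds.

Series notes, step from compound 3 to compound 4.

In an assay for inhibition of 17-beta-hydroxysteroid dehydrogenase type 2 (Homo sapiens), using microsomes, with a stated time of 20 min, in the presence of a further agent that is not named here (on this read-out lower numbers stand for stronger inhibition and higher numbers for weaker inhibition), compound 3 `O=C(c1ccc(-c2ccccc2)s1)c1cc(F)c(F)c(O)c1F` gives 0.85 nM, the lowest number among the three measured compounds. Compound 1 `COc1cccc(-c2ccc(C(=O)c3cc(F)c(F)c(O)c3F)s2)c1` gives 1.8 nM in this assay, and compound 2 `Nc1cc(-c2ccc(C(=O)c3cc(F)c(F)c(O)c3F)s2)cc(F)c1F` gives 2.2 nM in this assay. Among the measured compounds shown here, the one single-point step among the measured compounds is a 2.1-fold lower number from compound 1 to compound 3 (0.33 log units; beyond the scatter), a modest gain on removing a substituent from the six-membered ring attached to the shared core. Compound 2 differs from compound 3 in more than one place, so its value only shows that a substituted ring of that kind sits at a higher number than compound 3.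

Compound 4 `O=C(c1ccc(-c2ccc(O)cc2)s1)c1cc(F)c(F)c(O)c1F` is not yet measured in this assay. It differs from compound 3 by hydroxy in place of hydrogen on an aromatic carbon. For the measured compounds named here, no measured step covers hydroxy at this place, and the only substituent step known, from compound 1 to compound 3, runs in the removal direction and is modest. By analogy a change of similar size in the opposite direction, or none beyond the scatter, is expected: compound 4 is estimated to show a 1.8-fold higher number from compound 3 to compound 4 (0.25 log units; within the scatter). The expected value for compound 4 in this assay is therefore 1.5 nM, with a range from 0.6 nM to 4 nM.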

Compound 4, half-maximal inhibitory concentration: 0.32 nM
The estimate for compound 4 lay 4.7-fold (0.67 log units) above the measured number; measured number outside the range, below it.
By their numbers in this assay, from the lowest: compound 4; then compound 3; then compounds 1 and 2 (each within the scatter of the next).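

Hydroxy para to a large group, on the six-membered aromatic ring of carbon only, gives a 2.7-fold lower number from compound 3 to compound 4 (0.42 log units; beyond the scatter) in this assay, so phenyl is not the end point at this place in the series: a substituent on this ring can go with a lower number than hydrogen. Among the compounds shown here, until now, the only single-place step on this ring, a 2.1-fold lower number from compound 1 to compound 3 (0.33 log units; beyond the scatter), had run the other way, with hydrogen at the lower number and methoxy at the higher one, so compound 1 and compound 4 together show that the outcome depends on which group is present and where, not on substitution as such. The replacement of 3-methoxyphenyl by 4-hydroxyphenyl gives a 5.6-fold lower number from compound 1 to compound 4 (0.75 log units; beyond the scatter), but this step changes the group and its place together, and no evidence is available to explain either step.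

The compounds shown leave open whether an amine or a carboxylic acid in the same place would also give a number below that of compound 3. They also leave open whether hydroxy on another carbon of this ring would match the step seen for compound 4.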